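This account rests on a few compounds, and the source may have more. Where it says the series, first, only, none or still open, it means among the compounds named here.

Compound 1 `CC(C(=O)NCc1ccc(C(F)(F)F)nc1Br)c1ccc(NS(C)(=O)=O)c(F)c1`: 169 nM
Compound 2 `CCC1CCC(c2nc(C(F)(F)F)ccc2CNC(=O)C(C)c2ccc(NS(C)(=O)=O)c(F)c2)CC1`: 0.3 nM
Compound 3 `CC(C(=O)NCc1ccc(C(F)(F)F)nc1C1=CCCCC1)c1ccc(NS(C)(=O)=O)c(F)c1`: 0.7 nM

In an assay on CHO cells for antagonist activity at transient receptor potential cation channel subfamily V member 1 (Homo sapiens), read by FLIPR and calcium flux (a lower number here means a stronger inhibitor, a higher number a weaker inhibitor), compound 3 gives 0.7 nM, the second highest of the three numbers; it sits nearest compound 2, a 2.3-fold higher number from compound 2 to compound 3 (0.37 log units; beyond the scatter), and furthest from compound 1, a 240-fold lower number from compound 1 to compound 3 (2.38 log units; beyond the scatter). Compound 4 `CCC1CC=C(c2nc(C(F)(F)F)ccc2CNC(=O)C(C)c2ccc(NS(C)(=O)=O)c(F)c2)CC1` differs from compound 3 by ethyl in place of hydrogen on a saturated ring carbon. For the measured compounds named here, two measured steps bear on this. The step of a 240-fold lower number from compound 1 to compound 3 (2.38 log units; beyond the scatter) and the step of a 560-fold lower number from compound 1 to compound 2 (2.75 log units; beyond the scatter) both show the large gain that either ring brings over bromo; the step of a 2.3-fold higher number from compound 2 to compound 3 (0.37 log units; beyond the scatter) shows that a ring carrying ethyl gives a modestly lower number than the ring without it, though that step also changes ring saturation. The expected step of a 1.8-fold lower number from compound 3 to compound 4 (0.24 log units; within the scatter) is therefore a small lowering, near the scatter. Compound 4 is estimated at 0.4 nM, with a range from 0.15 nM to 1.2 nM.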

Compound 4, inhibition constant: 0.1 nM
For compound 4 the middle estimate is 4.0-fold (0.60 log units) above the measured one; the whole stated range lies above it.
By their numbers in this assay, from the lowest: compound 4; then compound 2; then compound 3; then compound 1.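

In this assay, ethyl on the saturated ring carbon matters by itself: a 7.0-fold lower number from compound 3 to compound 4 (0.85 log units; beyond the scatter) is a step beyond the scatter, and here the ring's saturation stays the same, unlike in the earlier comparison. With ethyl present, 4-ethylcyclohex-1-en-1-yl also outdoes 4-ethylcyclohexyl, a 3.0-fold lower number from compound 2 to compound 4 (0.48 log units; beyond the scatter), and replacing bromo with it gives a 1700-fold lower number from compound 1 to compound 4 (3.23 log units; beyond the scatter). No measurement here explains why these changes lower the number.

From the compounds shown here alone, whether this gain needs ethyl specifically stays open. A methyl, a longer chain such as propyl, or an amine on that ring carbon could show how much the group's identity matters.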